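This account rests on a few compounds, and the source may have more. Where it says the series, first, only, none or still open, it means among the compounds named here.

Compound 1 `Nc1nc(Cl)c(-c2ccco2)c(N[C@@H]2C[C@H](CO)[C@@H](O)[C@H]2O)n1`: > 25000 nM
Compound 2 `Cc1nc(NCC2CCC2)nc(N[C@@H]2C[C@H](CO)[C@@H](O)[C@H]2O)c1-c1nc2ccccc2s1`: > 25000 nM

In an ADME assay on cells (Homo sapiens) for cytotoxicity, read by polymerase chain reaction, with a stated time of 3 days (a lower number here means that less compound is tolerated, a higher number that more compound is tolerated), compound 1 gives > 25000 nM, which is a limit of the assay and not a number. Compound 2 likewise reaches only a limit in this assay, > 25000 nM. Compound 2 therefore stands at the limit of > 25000 nM in this assay, at which 2 of the 2 values shown sit, and nothing in the numbers sets it apart from compound 1.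

Compound 3 `Cc1nc(NCc2cccnc2)nc(N[C@@H]2C[C@H](CO)[C@@H](O)[C@H]2O)c1-c1nc2ccccc2s1` has not yet been measured. It differs from compound 2 in a single place: pyridin-3-yl in place of cyclobutyl on a saturated chain carbon bound to a nitrogen on an aromatic ring. For the measured compounds named here, no step between measured compounds is available to weigh this change. Going by the values given here, with the limit of > 25000 nM in this assay, at which 2 of the 2 values shown sit, as the only evidence, no direction can be read, and a step no larger than the scatter of this assay is expected. Compound 3 is expected to give about 30000 nM in this assay, within 10000 nM to 100000 nM. The expected step is a step that the limit leaves unreadable from compound 2 to compound 3, most likely reported once more only as a limit.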

Compound 3, half-maximal cytotoxic concentration: 5000 nM
The estimate for compound 3 lay 6.0-fold (0.78 log units) above the measured number, outside the stated range (below it).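

In this assay, replacing cyclobutyl with pyridin-3-yl on a saturated chain carbon bound to a nitrogen on an aromatic ring gives an at least 5.0-fold lower number from compound 2 to compound 3 (0.69 log units; beyond the scatter). For the compounds shown here, this shows that the group at this position can move the read-out beyond the scatter, which the earlier compounds could not show. Compound 3 is the only one of the compounds shown to give a number rather than a limit: the limit of > 25000 nM in this assay, at which 2 of the 3 values shown sit.

The compounds shown leave open whether the lower number goes with the ring nitrogen of pyridin-3-yl or with the aromatic ring as such, a question that phenyl in the same place would address. Going by these compounds, they also leave open how an amine or a longer chain would read there, and the full size of this step remains unknown, as its starting point is only a limit.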